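The compounds below may be only part of what the source reports. "The series", "measured", "known", "first", "only" and "open" are said of these compounds alone.

Compound 1 `Cc1ccc(-c2ccnc(Nc3ccc4c(c3)c(/C=C3/C(=O)Nc5ccccc53)cn4C)n2)cc1`: in a functional assay on U-87MG ATCC cells (Homo sapiens) for cytotoxicity, read by MTT assay, with a stated time of 48 h (on this read-out higher numbers stand for weaker inhibition and lower numbers for stronger inhibition), compound 1 gives only a limit, > 100000 nM.
Compound 2 `COc1ccc(-c2ccnc(Nc3ccc4c(c3)c(/C=C3/C(=O)Nc5ccccc53)cn4C)n2)cc1`: compound 2 likewise gives only a limit, > 100000 nM.
Compound 3 `Cn1cc(/C=C2/C(=O)Nc3ccccc32)c2cc(Nc3nccc(-c4ccc(O)cc4)n3)ccc21`: compound 3 gives 13200 nM.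

Among the compounds with values here, compound 3 thus holds the only real number among the three; the other two rest at the limit of > 100000 nM in this assay, at which 2 of the 3 values shown sit. The steps of an at least 7.5-fold lower number from compound 1 to compound 3 (0.87 log units; beyond the scatter) and an at least 7.5-fold lower number from compound 2 to compound 3 (0.87 log units; beyond the scatter) both show the hydroxy group yielding a lower number than methyl or methoxy, though their size can be read only as a bound. Compound 4 `Cn1cc(/C=C2/C(=O)Nc3ccccc32)c2cc(Nc3nccc(-c4ccc(F)cc4)n3)ccc21` carries fluoro in place of hydroxy on an aromatic carbon. Because the steps of an at least 7.5-fold lower number from compound 1 to compound 3 (0.87 log units; beyond the scatter) and an at least 7.5-fold lower number from compound 2 to compound 3 (0.87 log units; beyond the scatter) both run from a group without hydroxy to the hydroxy, compound 4, which again lacks hydroxy, is expected to move back toward the limit by a 4.5-fold higher number from compound 3 to compound 4 (0.66 log units; beyond the scatter). Compound 4 is therefore estimated at 60000 nM, within a range from 15000 nM to 200000 nM.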

Compound 4, half-maximal inhibitory concentration: 16400 nM
For compound 4 the middle estimate is 3.7-fold (0.56 log units) above the measured one, within the range that was stated.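

In this assay, the hydroxy group proves not to be required for a readable number on this aromatic carbon: with fluoro, which counts 0 hydrogen-bond donors, there is a 1.2-fold higher number from compound 3 to compound 4 (0.09 log units; within the scatter). Fluoro, like hydroxy, also separates from the other two groups, with an at least 6.0-fold lower number from compound 2 to compound 4 (0.78 log units; beyond the scatter) and an at least 6.0-fold lower number from compound 1 to compound 4 (0.78 log units; beyond the scatter). The size of these last two steps is only a bound: the limit of > 100000 nM in this assay, at which 2 of the 4 values shown sit.

The compounds shown leave open what hydrogen, chloro or an amine on this carbon would give. They also leave open why fluoro and hydroxy part from methyl and methoxy here.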